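Solubility notes on a hydroxyphenyl dienone series

The source may hold more compounds than are shown below. What is called first, only, known or untested is meant among the compounds shown, and "the series" means these compounds.

Measured so far:
compound 1 `COc1cc(/C=C/C2=CC(=O)CC(c3ccc(O)c(OC)c3)N2CCCO)ccc1O` gives 58900 nM
compound 2 `COc1cc(/C=C/C(=O)/C=C(/C=C/c2ccc(O)c(OC)c2)NCCCO)ccc1O` gives 25400 nM
compound 3 `COCCNC(=C\C(=O)/C=C/c1ccc(O)cc1)/C=C/c1ccc(O)cc1` gives 37500 nM

All three were run in a physicochemical assay for solubility, using the shake flask method, in phosphate buffer, with a stated time of 90 min, at pH 6.8; on this read-out higher numbers stand for higher solubility and lower numbers for lower solubility. The number for compound 3 sits between those of compound 2 and compound 1, and both gaps fall within the scatter, so the three cannot be told apart on this read-out.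

Compound 4 `COCCCNC(=C\C(=O)/C=C/c1ccc(O)cc1)/C=C/c1ccc(O)cc1` remains to be measured in this assay. It differs from compound 3 by methoxymethyl in place of methoxy on a saturated chain carbon, two bonds along the chain from an amine nitrogen. Within the data shown here, no step between two measured compounds is available to size this change, so the expectation rests on the closeness of the three numbers so far. The step is expected to be a 1.3-fold lower number from compound 3 to compound 4 (0.10 log units; within the scatter), not beyond the scatter. Compound 4 is expected at 30000 nM, with a range from 12000 nM to 75000 nM.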

Compound 4, solubility: 10500 nM
The estimate for compound 4 lay 2.9-fold (0.46 log units) above the measured number; the measured number lies below the stated range.
By their numbers in this assay, from the lowest: compound 4; then compounds 2, 3 and 1 (each within the scatter of the next, the first and the last beyond it).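

Among these compounds, the position is not indifferent in this assay: going from the 2-methoxyethyl to the 3-methoxypropyl chain gives a 3.6-fold lower number from compound 3 to compound 4 (0.55 log units; beyond the scatter) and is the first change that can be sized. Among the compounds shown here, the three earlier compounds lay within the scatter of one another and offered no step between compounds differing in one place. No available measurement bears on the reason for this step.

Still open, as far as these compounds go, is whether a longer chain would extend the step. Also open, from the compounds shown here alone, is how an amine or a carboxylic acid at the chain end would compare with the methoxy end.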